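This account rests on a few compounds, and the source may have more. Where it says the series, first, only, none or still open, it means among the compounds named here.

Working notes on the series. In a functional assay on MCF7 cells (Homo sapiens) for inhibition, read by CCK-8 assay, with a stated time of 48 h (on this read-out higher numbers stand for weaker inhibition of growth and lower numbers for stronger inhibition of growth), compound 1 (`Cc1ccc(Nc2ncc(Cl)c(Nc3ccccc3C)n2)cc1`) gives > 100000 nM, which is a limit and not a number. Compound 2 (`Cc1ccccc1Nc1nc(NCc2ccccc2)ncc1Cl`), with benzyl in place of 4-methylphenyl on a nitrogen on an aromatic ring, gives > 100000 nM, also a limit. Among the compounds with values here, the series so far therefore offers only (the limit of > 100000 nM in this assay, at which 2 of the 2 values shown sit). Within the data shown here, the one measured step, a step that the two limits leave unreadable from compound 1 to compound 2, has no size to carry forward.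

Compound 3 (`CCN1CCN(c2ccc(Nc3ncc(Cl)c(Nc4ccccc4C)n3)cc2)CC1`) changes compound 1 as follows: 4-ethylpiperazin-1-yl in place of methyl on an aromatic carbon. This places 4-ethylpiperazin-1-yl in place of methyl on an aromatic carbon, para to a large group. Among the measured compounds shown here, no measured step bears on this change, so any size is a judgement and the range stays wide. In this assay the expected move is an at least 6.6-fold lower number from compound 1 to compound 3 (0.82 log units; beyond the scatter), towards stronger inhibition. Another reading that is only a limit remains possible. Compound 3 is expected at 15000 nM, with an estimated range of 2500 nM to 90000 nM.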

Compound 3, concentration for 50% growth inhibition: 3160 nM
Estimate against measurement, compound 3: 4.7-fold (0.68 log units) above; the range from low to high includes it.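

In this assay, within the data shown here, placing 4-ethylpiperazin-1-yl in place of methyl on this aromatic carbon, para to a large group, gives the first step with a readable size: an at least 31-fold lower number from compound 1 to compound 3 (1.50 log units; beyond the scatter). The change brings in the six-membered non-aromatic ring with 2 hetero atoms and its ethyl end together, so the compounds shown cannot divide the step between these two parts. Compound 3 gives the only reading in the series that is a number, and the others are limits: the limit of > 100000 nM in this assay, at which 2 of the 3 values shown sit.

Still open, as far as these compounds go, is whether a morpholin-4-yl, an open-chain amine or a piperazine without the ethyl on this aromatic carbon would give a comparable number. Also open, from the compounds shown here alone, is whether compound 2 would respond to the same change.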